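The source may report more compounds than this note shows. Statements on the series, on what has been measured and on what is new or still open speak of the compounds shown alone.

Series notes, aryl and glycosyl triazole esters on a shared core.

Compound 1 `C/C(=C\CC/C(C)=C/CC[C@@H]1[C@@]2(C)CCC(=O)C(C)(C)[C@H]2CC[C@@]1(C)O)CC/C=C(\C)C(=O)OCc1cn(-c2ccc([N+](=O)[O-])cc2)nn1` carries a 4-nitrophenyl on the triazole ring nitrogen. In a functional assay on DU-145 cells (Homo sapiens) for antiproliferative activity, read by MTT assay, with a stated time of 48 h (on this read-out lower numbers stand for stronger inhibition and higher numbers for weaker inhibition), compound 1 gives only a limit, > 150000 nM, and no number. Among the compounds with values here, this is the only information on where compound 1 stands: the limit of > 150000 nM in this assay, at which 1 of the 2 values shown sits. Compound 2 `C/C(=C\CC/C(C)=C/CC[C@@H]1[C@@]2(C)CCC(=O)C(C)(C)[C@H]2CC[C@@]1(C)O)CC/C=C(\C)C(=O)OCc1cn(C[C@@H]2O[C@H](n3ccc(=O)[nH]c3=O)C[C@H]2O)nn1` bears the nucleoside-linked group on the same ring nitrogen instead; in this assay compound 2 gives 33100 nM. Within the data shown here, no single-site step between measured compounds is available, so the two values show only that compound 2 returns a number where compound 1 does not.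

Compound 3 `C/C(=C\CC/C(C)=C/CC[C@@H]1[C@@]2(C)CCC(=O)C(C)(C)[C@H]2CC[C@@]1(C)O)CC/C=C(\C)C(=O)OCc1cn(-c2cccc(C(F)(F)F)c2)nn1` is not yet measured. It differs from compound 1 in one place: 3-(trifluoromethyl)phenyl in place of 4-nitrophenyl on an aromatic nitrogen. Both groups are six-membered carbon-only aromatic rings on the triazole nitrogen, so compound 3 is expected to stay close to compound 1, with the likely outcome that this assay again reports a limit. The step of an at least 1.1-fold lower number from compound 1 to compound 3 (0.06 log units; that floor lies within the scatter) is expected to be none beyond the scatter, or at most a modest move toward stronger inhibition. Compound 3 is estimated at 130000 nM, with a range from 40000 nM to 400000 nM.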

Compound 3, half-maximal inhibitory concentration: > 150000 nM
Compound 3 ended at the assay's limit; the forecaster's own chance of this, stated with the estimate: 55%; at least 1.1-fold (0.06 log units) between middle value and limit.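

No step can be read between compound 1 and compound 3, since both end at a limit in this assay: the limit of > 150000 nM in this assay, at which 2 of the 3 values shown sit.

The compounds shown leave open how 3-(trifluoromethyl)phenyl and 4-nitrophenyl on the triazole nitrogen compare in this assay, with neither compound 1 nor compound 3 returning a number.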